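The source may report more compounds than this note shows. Statements on the series, on what has been measured and on what is new or still open speak of the compounds shown alone.

Measured in a functional assay on MKN-74 cells (Homo sapiens) for antiproliferative activity, with a stated time of 24 h; a higher number here means a weaker inhibitor, a lower number a stronger inhibitor:
Compound 1 `Cc1ccccc1CN1CCc2c(sc(NC(=O)c3ccccc3Cl)c2C(N)=O)C1`: > 50000 nM
Compound 2 `NC(=O)c1c(NC(=O)c2ccccc2Cl)sc2c1CCN(Cc1ccccc1F)C2`: 12900 nM

Compound 1 is reported only as > 50000 nM, which is a limit. Among the measured compounds shown here, compound 2, at 12900 nM, holds the only actual number so far. Compound 3 `NC(=O)c1c(NC(=O)c2ccccc2Cl)sc2c1CCN(Cc1ccc(Cl)cc1)C2` differs from compound 2 by 4-chlorophenyl in place of 2-fluorophenyl on a saturated chain carbon bound to an amine nitrogen in a ring, with 4-chlorophenyl in place of 2-fluorophenyl on a saturated chain carbon bound to an amine nitrogen in a ring. For the measured compounds named here, the one measured step, an at least 3.8-fold lower number from compound 1 to compound 2 (0.58 log units; beyond the scatter), puts fluoro in place of methyl on an aromatic carbon, and it gives only a loose guide to this different change. No step beyond the scatter is therefore expected, and the expected change is a 1.2-fold higher number from compound 2 to compound 3 (0.07 log units; within the scatter). For compound 3 the estimated value is 15000 nM, with an expected range of 5000 nM to 45000 nM.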

Compound 3, half-maximal inhibitory concentration: 18700 nM
Beside the measured number, compound 3's estimate is 1.2-fold (0.10 log units) below it; the range from low to high includes it.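

In this assay, 4-chlorophenyl in place of 2-fluorophenyl on this saturated chain carbon gives a 1.4-fold higher number from compound 2 to compound 3 (0.16 log units; within the scatter), so the two groups cannot be told apart here. Replacing 2-methylphenyl with 4-chlorophenyl gives an at least 2.6-fold lower number from compound 1 to compound 3 (0.42 log units; beyond the scatter), which shows that fluoro is not the only replacement on the aromatic ring linked to a step beyond the scatter. Compound 1 stands at a limit and not at a number: the limit of > 50000 nM in this assay, at which 1 of the 3 values shown sits.

This change alters the halogen and its ring position together, and the compounds shown do not separate the two. Going by these compounds, whether a pyridine ring, a cyclohexyl group or a longer chain here would move the number beyond the scatter remains open.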